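The compounds below may be only part of what the source reports. "The series", "measured", "known", "first", "only" and "open" are said of these compounds alone.

Measured so far:
- compound 1 `Cc1nn(-c2ncnc3nc[nH]c23)c2c1C(C(=O)N(C)c1nccs1)CC(=O)N2` — 3300 nM in a functional assay on HEK293 cells for agonist activity at G-protein coupled receptor 39 (Homo sapiens), read by scintillation proximity assay and inositol phosphate accumulation, with a stated time of 75 min; on this read-out higher numbers stand for an effect only at larger amounts of compound and lower numbers for an effect already at smaller amounts
- compound 2 `Cc1nn(-c2ncnc3nc[nH]c23)c2c1C(OC(=O)c1ccc(F)cc1)CC(=O)N2` — 245 nM in this assay

For the measured compounds named here, compound 2 holds the lowest number of the two in this assay; its nearest neighbour is compound 1, and the only measured step, a 13-fold lower number from compound 1 to compound 2 (1.13 log units; beyond the scatter), separates them. Going by the values given here, that step swaps the carbonyl-linked side group on the saturated ring carbon of the shared core, and it is the sole piece of evidence on how this position responds.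

Compound 3 `Cc1nn(-c2ncnc3nc[nH]c23)c2c1C(c1ccc(F)cc1Cl)CC(=O)N2` is the next entry. Against compound 2 the change is 2-chloro-4-fluorophenyl in place of ((4-fluorophenyl)carbonyl)oxy on a saturated ring carbon. Nothing measured covers an aryl ring placed directly on that carbon; the step from compound 1 to compound 2 shows only that the position tolerates a change of side group with a large movement in the number, so a step beyond the scatter in either direction is plausible for compound 3. The estimate therefore stays near compound 2 with a wide range: for compound 3 a value of 500 nM is expected in this assay, between 100 nM and 3000 nM, meaning an expected step of a 2.0-fold higher number from compound 2 to compound 3 (0.31 log units; beyond the scatter).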

Compound 3, half-maximal effective concentration: 280 nM
Estimate against measurement, compound 3: 1.8-fold (0.25 log units) above; the measured number falls inside the stated range.
By their numbers in this assay, from the lowest: compounds 2 and 3 (each within the scatter of the next); then compound 1.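

In this assay the 2-chloro-4-fluorophenyl group, set directly on the saturated ring carbon, gives a 1.1-fold higher number from compound 2 to compound 3 (0.06 log units; within the scatter) and so reads level with ((4-fluorophenyl)carbonyl)oxy; at this position, the carbonyl and oxygen link of compound 2 is therefore not required for a number of this size. Against methyl(1,3-thiazol-2-yl)carbamoyl, the same aryl group gives a 12-fold lower number from compound 1 to compound 3 (1.07 log units; beyond the scatter) and so, like the ester of compound 2, stands clearly apart from compound 1, which means that two different groups, one linked through carbonyl and oxygen and one attached directly, now share the lower level. Nothing measured on these compounds explains either step or the match between compound 2 and compound 3.

Still open, on these data alone, is whether the chlorine, the fluorine or both are needed on the directly attached ring, which a plain phenyl group would help to settle. Also open, as far as these compounds go, is how an amine, a carboxylic acid or a longer chain ending in a phenyl ring on the same saturated ring carbon would read in this assay against these two groups.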